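Peracetylated sugar thioureas in the biphenylsulfonyl valine series

A few compounds are considered here, and "the series" means these few. Any claim that something is new, unique, unknown or untested is made for them only; others in the source may bear on it.

Three compounds of the shared core have numbers in an assay on isolated protein for inhibition of matrix metalloproteinase-9 (Homo sapiens), read by fluorescence, with stated times of 3 h, 10 s and 15 min; a lower number here means a stronger inhibitor, a higher number a weaker inhibitor. Compound 1 `CO[C@@H]1O[C@H](CNC(=S)NCCN([C@@H](C(=O)O)C(C)C)S(=O)(=O)c2ccc(-c3ccccc3)cc2)[C@@H](O)[C@H](O)[C@H]1O` gives 520 nM. Compound 3 `CO[C@@H]1O[C@H](CN([C@@H](C(=O)O)C(C)C)S(=O)(=O)c2ccc(-c3ccccc3)cc2)[C@@H](O)[C@H](O)[C@H]1NC(C)=O` gives 890 nM. Compound 2 `CC(=O)N[C@@H]1[C@@H](OC(C)=O)[C@H](OC(C)=O)[C@@H](COC(C)=O)O[C@H]1NC(=S)NCCN([C@@H](C(=O)O)C(C)C)S(=O)(=O)c1ccc(-c2ccccc2)cc1` gives 1200 nM, the highest of the three numbers; the gap to compound 3 lies within the scatter, whereas compound 1 sits beyond the scatter with the lower number.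

The next compound, compound 4 `CC(=O)OC[C@H]1O[C@@H](NC(=S)NCCN([C@@H](C(=O)O)C(C)C)S(=O)(=O)c2ccc(-c3ccccc3)cc2)[C@H](OC(C)=O)[C@@H](OC(C)=O)[C@@H]1OC(C)=O`, differs from compound 2 by acetoxy in place of acetamido on a saturated ring carbon. Within the data shown here, no step between two measured compounds isolates this exchange, so the expected step in this assay rests on compound 2 alone and is expected to be none beyond the scatter, a 1.1-fold lower number from compound 2 to compound 4 (0.04 log units; within the scatter). Compound 4 is therefore estimated at 1100 nM, within 400 nM to 3000 nM.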

Compound 4, half-maximal inhibitory concentration: 880 nM
Estimate against measurement, compound 4: 1.3-fold (0.10 log units) above; the measured number falls inside the stated range.
By their numbers in this assay, from the lowest: compounds 1, 4, 3 and 2 (each within the scatter of the next, the first and the last beyond it).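

In this assay, acetoxy in place of acetamido on this saturated ring carbon, next to the ring atom that bears a large group, gives a 1.4-fold lower number from compound 2 to compound 4 (0.13 log units; within the scatter) in the peracetylated thiourea series. The position therefore tolerates going from 1 hydrogen-bond donor to 0 donors, and from 1 acceptor to 2, with no step beyond the scatter. Nothing available accounts for this tolerance. Going by these compounds, whether an amine, a free hydroxyl or a longer acyl chain at this position would shift the number beyond the scatter remains open.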